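Working notes: methoxy added to compound 2

The source may hold more compounds than are shown below. What is called first, only, known or untested is meant among the compounds shown, and "the series" means these compounds.

compound 1 `C#Cc1cccc(Nc2ncnc3cc(NC(=O)/C=C/c4ccccc4)sc23)c1` gives 75600 nM
compound 2 `O=C(/C=C/c1ccccc1)Nc1cc2ncnc(Nc3ccc(F)c(Cl)c3)c2s1` gives 30900 nM
compound 3 `O=C(/C=C/c1ccccc1)Nc1cc2ncnc(Nc3cc(Cl)cc(Cl)c3)c2s1` gives > 100000 nM (a limit of the assay, not a number)

Within the data shown here, in a functional assay on MCF7 cells (Homo sapiens) for antiproliferative activity, read by MTT assay, with a stated time of 48 h (on this read-out lower numbers stand for stronger inhibition and higher numbers for weaker inhibition), compound 2 holds the lower of the only two true numbers, and compound 1 is its nearest neighbour. Compound 4 `COc1ccc(/C=C/C(=O)Nc2cc3ncnc(Nc4ccc(F)c(Cl)c4)c3s2)cc1` has methoxy in place of hydrogen on an aromatic carbon, which turns phenyl to 4-methoxyphenyl methoxy in place of hydrogen on an aromatic carbon and leaves the rest of compound 2 unchanged.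

Among the measured compounds shown here, no measured step touches this phenyl. All of them exchange the aryl group on a nitrogen, so they bear only indirectly and set a rough scale for the series. The measured steps are a 2.4-fold lower number from compound 1 to compound 2 (0.39 log units; beyond the scatter) and an at least 3.2-fold higher number from compound 2 to compound 3 (0.51 log units; beyond the scatter) and both are modest or open-ended through the limit. In this assay a step of no more than that modest size is therefore expected, with no direction fixed by the data and most likely none beyond the scatter. The estimated step is a 1.2-fold lower number from compound 2 to compound 4 (0.09 log units; within the scatter) in this expectation. The estimated value for compound 4 is 25000 nM with an expected range of 8000 nM to 80000 nM on this read-out.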

Compound 4, half-maximal inhibitory concentration: 29100 nM
For compound 4 the middle estimate is 1.2-fold (0.07 log units) below the measured one; the measured number falls inside the stated range.
By their numbers in this assay, from the lowest: compounds 4 and 2 (each within the scatter of the next); then compound 1. At a limit, above all of these: compound 3.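

Methoxy in place of hydrogen on an aromatic carbon, para to a large group, is the only step shown on the phenyl of the 2-phenylethenyl group, and in this assay it gives a 1.1-fold lower number from compound 2 to compound 4 (0.03 log units; within the scatter) and so leaves compound 2 and compound 4 indistinguishable. Among these compounds, two of the earlier steps on the aryl group on a nitrogen reach beyond the scatter, a 2.4-fold lower number from compound 1 to compound 2 (0.39 log units; beyond the scatter) and an at least 3.2-fold higher number from compound 2 to compound 3 (0.51 log units; beyond the scatter) while this single change on the phenyl does not. Nothing on hand bears on the reason for this result.

From the compounds shown here alone, whether an amine or a carboxylic acid in the place of methoxy would read the same stays open. Also open, going by these compounds, is whether 4-methoxyphenyl would read the same alongside the 3-ethynylphenyl of compound 1.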